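A few compounds are considered here, and "the series" means these few. Any claim that something is new, unique, unknown or untested is made for them only; others in the source may bear on it.

The measured compounds:
Compound 1 `Cc1cc(C)cc(S(=O)(=O)n2c(=S)[nH]c3ccccc32)c1`; in an ADME assay on MT4 cells (Homo sapiens) for cytotoxicity (a lower number here means that less compound is tolerated, a higher number that more compound is tolerated), compound 1 gives 41000 nM.
Compound 2 `Cc1cc(C)cc(S(=O)(=O)n2c(=S)[nH]c3ccc(Cl)cc32)c1`; in this assay compound 2 gives 93100 nM.
Compound 3 `Cc1cc(C)cc(S(=O)(=O)n2c(SCC(=O)Nc3ccc(S(N)(=O)=O)cc3Cl)nc3ccccc32)c1`; in this assay compound 3 gives 25600 nM.

Compound 1 and compound 2 share a core and differ in one place: chloro in place of hydrogen on an aromatic carbon. This change gave a 2.3-fold higher number from compound 1 to compound 2 (0.36 log units; beyond the scatter). Compound 3 carries a different core; how the core of compound 3 differs from the core of compound 1 is not broken down here. Compound 4 `Cc1cc(C)cc(S(=O)(=O)n2c(SCC(=O)Nc3ccc(S(N)(=O)=O)cc3Cl)nc3ccc(Cl)cc32)c1` has not yet been measured. Among the measured compounds shown here, it differs from compound 3 by chloro in place of hydrogen on an aromatic carbon, which is the same change as the one from compound 1 to compound 2, in the same kind of place. Only that one earlier example of the change exists among these compounds, so the expectation rests on it alone. From compound 3 to compound 4 a step of about the same size is expected in this assay, a 2.3-fold higher number from compound 3 to compound 4 (0.36 log units; beyond the scatter). That expectation rests on compound 1 and compound 2, where the same change gave a 2.3-fold higher number from compound 1 to compound 2 (0.36 log units; beyond the scatter). Compound 4 is therefore estimated at 58000 nM, with a likely range from 30000 nM to 120000 nM.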

Compound 4, half-maximal cytotoxic concentration: 23400 nM
Compound 4: the middle estimate sits 2.5-fold (0.39 log units) above what was measured, outside the stated range (below it).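

In this assay, chloro in place of hydrogen on an aromatic carbon gave a 1.1-fold lower number from compound 3 to compound 4 (0.04 log units; within the scatter), so on this core the two compounds cannot be told apart. Set beside the one earlier example of the same change, this step does not differ from it by more than repeated measurements could account for: the same change on two cores in this assay, a 2.3-fold higher number (0.36 log units; beyond the scatter) from compound 1 to compound 2 and a 1.1-fold lower number (0.04 log units; within the scatter) from compound 3 to compound 4, 2.5-fold (0.40 log units) apart, within the scatter of two such steps. This does not show that the change acts alike on both cores, nor that it acts differently, since two pairs cannot separate a real difference between cores from ordinary scatter, and they say nothing about a third core.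

The compounds shown carry only chloro at this place on the ring, so it remains open whether fluoro, methyl or methoxy there would give a step of similar size. Going by these compounds, it also remains open whether chloro at another carbon of that ring would behave in the same way on either core.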